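The source may hold more compounds than are shown below. What is called first, only, known or untested is meant among the compounds shown, and "the series" means these compounds.

Compound 1 `N#Cc1ccc2c(Oc3ccc(F)cc3OCCn3ccc(=O)[nH]c3=O)cc(Cl)cc2c1` gives 16000 nM in an ADME assay on MT2 cells (Homo sapiens) for cytotoxicity, read by MTT assay; on this read-out lower numbers stand for higher toxicity in this test and higher numbers for lower toxicity in this test.
Compound 2 `N#Cc1ccc2c(Oc3ccccc3OCCn3ccc(=O)[nH]c3=O)cc(Cl)cc2c1` gives 24000 nM in this assay.

For the measured compounds named here, only two numbers are known, and compound 2 sits within the scatter of compound 1, so neither stands apart. Compound 3 `N#Cc1ccc2c(Oc3ccc(Cl)cc3OCCn3ccc(=O)[nH]c3=O)cc(Cl)cc2c1` differs from compound 2 by chloro in place of hydrogen on an aromatic carbon. Going by the values given here, the one measured step that bears on this is a 1.5-fold higher number from compound 1 to compound 2 (0.18 log units; within the scatter), which replaced a halogen by hydrogen at that same aromatic carbon without a change beyond the scatter. Putting a chloro there is therefore expected to leave the reading about where it is, a 1.5-fold lower number from compound 2 to compound 3 (0.18 log units; within the scatter). Compound 3 is estimated at 16000 nM, with a range of 6000 nM to 40000 nM.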

Compound 3, half-maximal cytotoxic concentration: 20000 nM
Estimate against measurement, compound 3: 1.3-fold (0.10 log units) below; the measured number falls inside the stated range.
By their numbers in this assay, from the lowest: compounds 1, 3 and 2 (each within the scatter of the next).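

Hydrogen, fluoro and chloro have now all been placed on this one aromatic carbon, and in this assay the readings stay within the scatter of one another (a 1.2-fold lower number from compound 2 to compound 3 (0.08 log units; within the scatter)) and (a 1.3-fold higher number from compound 1 to compound 3 (0.10 log units; within the scatter)). Chloro therefore agrees with fluoro: across these three compounds, neither halogen separates from hydrogen in this test. Nothing available explains why these readings stay together. Still open, from the compounds shown here alone, is whether a different kind of group on this carbon, such as an amine or a carboxylic acid, would move the reading beyond the scatter.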